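A few compounds are considered here, and "the series" means these few. Any claim that something is new, unique, unknown or untested is made for them only; others in the source may bear on it.

In a functional assay on MCF7 cells (Homo sapiens) for cytotoxicity, read by MTT assay, with a stated time of 24 h (on this read-out lower numbers stand for stronger inhibition and higher numbers for weaker inhibition), compound 1 (`Cc1ccc(Cl)cc1S(=O)(=O)Nc1ccc(Cl)c(Cl)c1`) gives 57300 nM and compound 2 (`Cc1ccc(NS(=O)(=O)c2cc(Cl)sc2Cl)cc1`) gives 66100 nM so the two cannot be told apart, and compound 2 stands level with compound 1 within the scatter. Among the compounds with values here, compound 3 (`Cc1ccc(N(SC(Cl)(Cl)Cl)S(=O)(=O)c2cc(Cl)sc2Cl)cc1`) differs from compound 2 by (trichloromethyl)sulfanyl in place of hydrogen on a sulfonamide nitrogen and no measured pair shows what such a change does. An expected 4.4-fold lower number from compound 2 to compound 3 (0.64 log units; beyond the scatter) would be a moderate move toward stronger inhibition, beyond the scatter but uncertain. For compound 3 the estimated value is 15000 nM with an expected range from 3000 nM to 60000 nM in this test series.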

Compound 3, half-maximal inhibitory concentration: 30100 nM
Compound 3: the middle estimate sits 2.0-fold (0.30 log units) below what was measured, and the stated range covers the measured number.
By their numbers in this assay, from the lowest: compounds 3, 1 and 2 (each within the scatter of the next, the first and the last beyond it).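

In this assay, within the data shown here, the first change at a single place, (trichloromethyl)sulfanyl in place of hydrogen on a sulfonamide nitrogen, gives a 2.2-fold lower number from compound 2 to compound 3 (0.34 log units; beyond the scatter) and so moves modestly toward stronger inhibition. This nitrogen can therefore lose its hydrogen and carry this group without any loss of inhibition in these cells. No available measurement explains the step. Open, from the compounds shown here alone, is whether a plain methyl or an acetyl group on the same nitrogen would give a similar step. Also open, going by these compounds, is whether the same change would act alike on the core of compound 1.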